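The source may hold more compounds than are shown below. What is called first, only, known or untested is meant among the compounds shown, and "the series" means these compounds.

Among the measured compounds shown here, compound 2 `COc1ccc(-c2nn3c(-c4ccc(OC)c(OC)c4)nnc3s2)cc1N` gives 522 nM in a functional assay on A549 cells (Homo sapiens) for antiproliferative activity, read by MTT assay, with a stated time of 72 h (on this read-out lower numbers stand for stronger inhibition and higher numbers for weaker inhibition), the higher of the two numbers measured so far, while compound 1 `COc1ccc(-c2nn3c(-c4ccc(OC)c(OC)c4OC)nnc3s2)cc1N` gives 82 nM. Compound 3 `COc1cccc(-c2nnc3sc(-c4ccc(OC)c(N)c4)nn23)c1` differs from compound 2 by hydrogen in place of methoxy on an aromatic carbon. For the measured compounds named here, the only measured step that bears on this change is a 6.4-fold higher number from compound 1 to compound 2 (0.80 log units; beyond the scatter), which also removed a methoxy from an aromatic carbon. A step in the same direction, likely somewhat smaller, is therefore expected from compound 2 to compound 3: a 3.1-fold higher number from compound 2 to compound 3 (0.49 log units; beyond the scatter). In this assay compound 3 is estimated at 1600 nM, with a range from 500 nM to 5000 nM.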

Compound 3, half-maximal inhibitory concentration: 120 nM
Estimate against measurement, compound 3: 13-fold (1.12 log units) above; the whole stated range lies above it.
By their numbers in this assay, from the lowest: compounds 1 and 3 (each within the scatter of the next); then compound 2.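

In this assay, taking away the methoxy that sits para to a large group gave a 4.4-fold lower number from compound 2 to compound 3 (0.64 log units; beyond the scatter) and so ran against a 6.4-fold higher number from compound 1 to compound 2 (0.80 log units; beyond the scatter) on the same ring. Replacing a methoxy with hydrogen on this ring therefore has no single direction across these compounds, and the result depends on which methoxy leaves. No measurement shown here accounts for the difference between the two steps.
The compounds shown leave open how a hydroxyl, a fluorine or an amine on this carbon would compare with hydrogen and methoxy.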